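A few compounds are considered here, and "the series" means these few. Any claim that something is new, unique, unknown or untested is made for them only; others in the source may bear on it.

Compound 1 `COc1cc(/C=C/C(C)=O)ccc1OCc1cn(-c2ccccc2OC)nn1` carries a 2-methoxyphenyl on the five-membered aromatic ring of the shared core. In a functional assay on MCF7 cells (Homo sapiens) for antiproliferative activity, read by MTT assay, with a stated time of 48 h (on this read-out lower numbers stand for stronger inhibition and higher numbers for weaker inhibition), compound 1 gives 29100 nM. Among the values measured so far it is the only number recorded; the other value is a limit. Compound 2 `CCOC(=O)c1ccc(-n2cc(COc3ccc(/C=C/C(C)=O)cc3OC)nn2)cc1` reaches only a limit in this assay, recorded as > 100000 nM, which is the limit of the assay rather than a number, the case described by the limit of > 100000 nM in this assay, at which 1 of the 2 values shown sits. Among the compounds with values here, no step between two measured compounds that differ in one place is available, so the size of the move from compound 1 to an analogue changed at a single position has no direct precedent here.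

Compound 3 `COc1cc(/C=C/C(C)=O)ccc1OCc1cn(-c2cc(F)cc(Br)c2)nn1` differs from compound 1 in one place (3-bromo-5-fluorophenyl in place of 2-methoxyphenyl on an aromatic nitrogen). The change is expected to shift the value in this assay by a 1.3-fold lower number from compound 1 to compound 3 (0.12 log units; within the scatter), no more than the usual scatter of repeated measurements, in the direction of stronger inhibition if anything. Compound 3 is therefore estimated to give 22000 nM in this assay, with a range from 7000 nM to 70000 nM, and with some chance that only a limit is reported.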

Compound 3, half-maximal inhibitory concentration: 65500 nM
The estimate for compound 3 lay 3.0-fold (0.47 log units) below the measured number; low and high end bracket the measured number.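

Placing 3-bromo-5-fluorophenyl in place of 2-methoxyphenyl on an aromatic nitrogen gives the first single-place step at this position in this assay: a 2.3-fold higher number from compound 1 to compound 3 (0.35 log units; beyond the scatter). This shows that the read-out responds to which aryl group sits on this nitrogen, even though the group that leaves and the group that enters both have 8 heavy atoms and one six-membered aromatic ring of carbon only, and here the move runs towards weaker inhibition. The group that leaves has 1 hydrogen-bond acceptor and the group that enters has 0, but the methoxy group is lost and the bromine and fluorine are gained in a single change, and nothing shown gives a cause for the step.

The compounds shown leave open whether the bromine, the fluorine or the loss of the methoxy group carries the step, which a phenyl bearing only one of these halogens could separate. Also open, from the compounds shown here alone, is how an unsubstituted phenyl, or a phenyl bearing an amine or a carboxylic acid, would read in this assay at this position.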